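Methyl groups on the thiophene of compound 2

This account rests on a few compounds, and the source may have more. Where it says the series, first, only, none or still open, it means among the compounds named here.

In a functional assay on cells (Cancer cell lines, Homo sapiens) for inhibition (on this read-out lower numbers stand for stronger inhibition of growth and higher numbers for weaker inhibition of growth), compound 1 (`Cc1cn2c(/C=N/NC(=N)N)c(-c3ccsc3)nc2s1`) gives 6920 nM and compound 2 (`N=C(N)N/N=C/c1c(-c2ccsc2)nc2sccn12`) gives 15100 nM, the higher of these two numbers and so the weaker inhibition of growth. Compound 3 (`Cc1cc(-c2nc3sccn3c2/C=N/NC(=N)N)c(C)s1`) has not yet been measured. It carries 2,5-dimethylthiophen-3-yl in place of thiophen-3-yl on an aromatic carbon. Among the measured compounds shown here, only one measured step bears on this change, and only loosely, since its methyl sits elsewhere on the molecule. Going by a 2.2-fold higher number from compound 1 to compound 2 (0.34 log units; beyond the scatter), a modest step in which hydrogen takes the place of methyl, the methyl groups gained in compound 3 are expected to bring a step of similar size towards a lower number in this assay. The estimated change is a 2.2-fold lower number from compound 2 to compound 3 (0.33 log units; beyond the scatter). For compound 3 the expected value is 7000 nM, with an estimated range from 2800 nM to 16000 nM.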

Compound 3, concentration for 50% growth inhibition: 15500 nM
Compound 3: middle estimate off by 2.2-fold (0.35 log units), on the low side, within the range that was stated.
By their numbers in this assay, from the lowest: compound 1; then compounds 2 and 3 (each within the scatter of the next).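

In this assay, 2,5-dimethylthiophen-3-yl in place of thiophen-3-yl gives a 1.0-fold higher number from compound 2 to compound 3 (0.01 log units; within the scatter), so compound 2 and compound 3 cannot be told apart on this read-out. This aromatic carbon of the shared core thus takes the larger group, with its two added methyl groups, without a measurable change in growth inhibition, whereas the methyl elsewhere on the molecule does show a step, a 2.2-fold higher number from compound 1 to compound 2 (0.34 log units; beyond the scatter). Nothing measured here explains why a methyl change registers in one place and not in the other.

Whether the two methyl groups each have no effect, or have separate effects that cancel, stays open, since a thiophene carrying only one methyl is not among the compounds shown. Also open, as far as these compounds go, is how this position responds to a quite different group, such as a phenyl ring in place of the thiophene or an amine attached to it.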